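Methoxyphenyl positional swap on two enone cores

The source may hold more compounds than are shown below. What is called first, only, known or untested is meant among the compounds shown, and "the series" means these compounds.

Compound 1 `COc1cccc(/C=C/C(=O)c2ccc(OCCn3cc(CN4C(=O)/C=C/C(C)(C)C/C=C(\C)CC/C=C/4C)nn3)cc2O)c1` and compound 2 `COc1ccccc1/C=C/C(=O)c1ccc(OCCn2cc(CN3C(=O)/C=C/C(C)(C)C/C=C(\C)CC/C=C/3C)nn2)cc1O` share one core; compound 3 `COc1cccc(/C=C/C(=O)c2ccc(OCCCN3C(=O)/C=C/C(C)(C)C/C=C(\C)CC/C=C/3C)cc2)c1` and compound 4 `COc1ccccc1/C=C/C(=O)c1ccc(OCCCN2C(=O)/C=C/C(C)(C)C/C=C(\C)CC/C=C/2C)cc1` share another. The difference between the two cores is not broken down here.

In a functional assay on MCF7 cells (Homo sapiens) for antiproliferative activity (a lower number here means a stronger inhibitor, a higher number a weaker inhibitor), compound 1 gives 1.12 ug/mL. With the change 2-methoxyphenyl in place of 3-methoxyphenyl on a double-bonded chain carbon bound to a double-bonded chain carbon compound 2 gives 1.17 ug/mL; the step is a 1.0-fold higher number from compound 1 to compound 2 (0.02 log units; within the scatter). On the other core, compound 3 gives 1.37 ug/mL in this assay, a number that sits within the scatter of compound 1 and compound 2.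

Compound 4 carries the same change, (2-methoxyphenyl in place of 3-methoxyphenyl on a double-bonded chain carbon bound to a double-bonded chain carbon), made on the core of compound 3. Within the data shown here, the one measured instance of this change, from compound 1 to compound 2, left the number unmoved, so the expected step in this assay is likewise small, a 1.0-fold higher number from compound 3 to compound 4 (0.01 log units; within the scatter), an expectation that rests only on that single pair.

Compound 4 is therefore estimated at 1.4 ug/mL in this assay, expected to fall between 0.8 ug/mL and 2.5 ug/mL.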

Compound 4, half-maximal inhibitory concentration: 1.56 ug/mL
For compound 4 the middle estimate is 1.1-fold (0.05 log units) below the measured one; low and high end bracket the measured number.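

In this assay the change from 3-methoxyphenyl to 2-methoxyphenyl gives a 1.1-fold higher number from compound 3 to compound 4 (0.06 log units; within the scatter), and the two cores agree closely on this step: the same change on two cores in this assay, a 1.0-fold higher number (0.02 log units; within the scatter) from compound 1 to compound 2 and a 1.1-fold higher number (0.06 log units; within the scatter) from compound 3 to compound 4, 1.1-fold (0.04 log units) apart, within the scatter of two such steps

Across these two cores, the change therefore carries over as a step within the scatter on each, and the two methoxyphenyl isomers cannot be told apart in this assay. This does not show that the change would stay as small on a third core or in another assay, and two steps this small cannot separate a slight real effect from none at all.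

As far as these compounds go, all four compounds carry a methoxyphenyl group on the enone, so it remains open whether any replacement there would move the number beyond the scatter, for example an amine or a carboxylic acid in place of the methoxy group. From the compounds shown here alone, the contribution of the difference between the two cores also remains open, as does the effect of a longer chain to the shared large ring.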